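Title: Ethyl in place of methyl on an inactive chloropyridine anilide

The source may report more compounds than this note shows. Statements on the series, on what has been measured and on what is new or still open speak of the compounds shown alone.

The series is read in a functional assay on cells for agonist activity at D(4) dopamine receptor (Homo sapiens), read by TR-FRET and cAMP accumulation, with a stated time of 30 min; a lower number here means a smaller maximal response, a higher number a larger maximal response. Compound 1, `CCc1cccc(NC(=O)CN2CCN(c3ccccn3)CC2)c1`, gives 58%, the only numeric response in the set. Compound 2, `Cc1cccc(NC(=O)CN2CCN(c3ccc(Cl)cn3)CC2)c1`, is reported as "not active" (no number reported), with no single number attached, and compound 3, `Cc1ccc(C2CCN(CC(=O)Nc3cccc(C)c3)CC2)cc1`, is likewise reported as "not active" (no number reported); so compound 2 stands among two entries without a number, while compound 1 alone carries a value. Within the data shown here, compound 1 and compound 2 differ in more than one place, so no single step connects them.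

Compound 4, `CCc1cccc(NC(=O)CN2CCN(c3ccc(Cl)cn3)CC2)c1`, has not yet been measured. It differs from compound 2 by methyl in place of hydrogen on a saturated chain carbon bound to an aromatic carbon.

Among the measured compounds shown here, since no step between measured compounds is available, the expected size of the change in this assay from compound 2 to compound 4 cannot be read from a parallel pair; the author expects a small move upward at most, quite possibly none beyond the scatter. The estimate for compound 4 in this assay is 25%, with a range from 0% to 55%, and it is thought fairly likely that compound 4, like compound 2, will be reported without a number.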

Compound 4, largest response reached (Emax), in percent of the reference or control that the assay uses: "not active" (no number reported)
Compound 4 has no reported number here, and the estimate cannot be compared.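

Among these compounds, compound 4, like compound 2, is reported as "not active" in this assay, so no step from methyl to ethyl can be read between them. No measurement here bears on why either compound gives no response. The compounds shown leave open whether any single change to the chloropyridine anilide restores a measurable response.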